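Methyl to Ethyl on an Aromatic Nitrogen

The compounds below may be only part of what the source reports. "The series", "measured", "known", "first", "only" and "open" are said of these compounds alone.

Compound 1, `c1ccc(-c2cn[nH]c2)c(NCC2=NCCN2)c1`: 1.26 nM
Compound 2, `Cn1cc(-c2ccccc2NCC2=NCCN2)cn1`: 398 nM

Among the measured compounds shown here, in an in vitro functional assay on cells (Fibroblast) for agonist activity at Alpha-1A adrenergic receptor (Homo sapiens) (a higher number here means that more compound is needed for the effect, a lower number that less compound is needed), compound 2 stands at the higher of the two measured numbers, with compound 1 as its only neighbour; the step of a 320-fold higher number from compound 1 to compound 2 (2.50 log units; beyond the scatter) shows how strongly this position responds to substitution. Compound 3, `CCn1cc(-c2ccccc2NCC2=NCCN2)cn1`, differs from compound 2 by methyl in place of hydrogen on a saturated chain carbon bound to an aromatic nitrogen. For the measured compounds named here, only the step from compound 1 to compound 2 bears on this site, and it concerns adding a group, not lengthening one, so it gives no direct guide for methyl to ethyl. A modest further increase in the number is expected for compound 3, as a 1.5-fold higher number from compound 2 to compound 3 (0.18 log units; within the scatter), since the site already proved sensitive. Compound 3 is therefore estimated at 600 nM, within 150 nM to 2500 nM.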

Compound 3, half-maximal effective concentration: < 100000 nM
Compound 3 was reported as a limit; the forecaster's own chance of this, stated with the estimate: 10%; the middle value does not contradict the limit.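

In this assay, among the compounds shown here, compound 3 gives < 100000 nM as a limit and not a number, so no step from compound 1 or compound 2 to compound 3 can be read. As far as these compounds go, how ethyl compares with methyl or hydrogen on the aromatic nitrogen stays open.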